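This account rests on a few compounds, and the source may have more. Where it says the series, first, only, none or still open, it means among the compounds named here.

Measured compounds:
- compound 1, `O=C(Oc1ccc(-c2cncn2C2CCN(C(=O)c3ccc(Cl)c(C(F)(F)F)c3)CC2)cc1)c1ccccc1` — in an assay on HEK293 cells for antagonist activity at P2X purinoceptor 7 (Homo sapiens), read by fluorescence, with a stated time of 2 h (a lower number here means a stronger inhibitor, a higher number a weaker inhibitor), compound 1 gives > 10000 nM, which is a limit of the assay rather than a number.
- compound 2, `O=C(NC1CC1)c1cccc(S(=O)(=O)Oc2ccc(-c3cncn3C3CCN(C(=O)c4ccc(Cl)c(C(F)(F)F)c4)CC3)cc2)c1` — in this assay compound 2 gives 88 nM.
- compound 3, `COc1ccc(C(=O)N2CCC(n3cncc3-c3ccc(OS(=O)(=O)c4cccc5cnccc45)cc3)CC2)cc1` — in this assay compound 3 gives 77 nM.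

Of the two numbers shown, compound 3 and compound 2 sit within the scatter of each other, so no order between them can be read from this assay. Compound 1 stands apart only as the limit of > 10000 nM in this assay, at which 1 of the 3 values shown sits; no step between two measured compounds that differ in one place is shown, so the shared core carries no measured step to lean on.

Compound 4, `CS(=O)(=O)c1ccc(C(=O)N2CCC(n3cncc3-c3ccc(OS(=O)(=O)c4cccc5cnccc45)cc3)CC2)cc1`, has not been measured. It differs from compound 3 in one place: methylsulfonyl in place of methoxy on an aromatic carbon — methylsulfonyl in place of methoxy on an aromatic carbon, para to a large group, with the rest of the molecule held the same.

With no measured step of this kind in the series, the expectation for compound 4 rests on compound 3 at 77 nM and on the small size of the change at one edge of the molecule. A step from compound 3 to compound 4 of a 1.6-fold higher number from compound 3 to compound 4 (0.19 log units; within the scatter) is expected, in the direction of a somewhat higher number, but not clearly beyond the scatter. For compound 4 the estimate in this assay is 120 nM, with a range from 40 nM to 400 nM.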

Compound 4, half-maximal inhibitory concentration: 25 nM
Estimate against measurement, compound 4: 4.8-fold (0.68 log units) above; the measured number lies below the stated range.
By their numbers in this assay, from the lowest: compound 4; then compounds 3 and 2 (each within the scatter of the next). At a limit, above all of these: compound 1.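

The series now holds its first measured step between compounds that differ in one place: in this assay, methylsulfonyl in place of methoxy on an aromatic carbon, para to a large group, gives a 3.1-fold lower number from compound 3 to compound 4 (0.49 log units; beyond the scatter). This edge of the molecule is therefore not silent in this assay, and methylsulfonyl, with 4 heavy atoms against 2 for methoxy, goes with a lower number here rather than a higher one, though this rests on a single pair with the rest of the molecule held the same. Nothing measured on these compounds bears on why the number moves, and the one limit in the set has no connection to this step.

The compounds shown leave open whether a nitrile, a primary sulfonamide, a carboxylic acid or an amine at this same place would sit with methylsulfonyl or with methoxy, and whether a longer chain on the sulfonyl group, such as ethylsulfonyl, would keep the lower number. Also open, as far as these compounds go, is whether the same change gives a step of like size when the other end of the molecule is different.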